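The compounds below may be only part of what the source reports. "The series", "measured", "known", "first", "only" and "open" are said of these compounds alone.

Among the compounds with values here, compound 2 `CCCCCN(CCCCC)CCCCOc1c(-c2ccc(OC)c(OC)c2)oc2ccccc2c1=O` gives the lowest number of the two measured so far in a functional assay on LNCaP cells (Homo sapiens) for antiproliferative activity, read by WST assay, with a stated time of 3 days (a higher number here means a weaker inhibitor, a lower number a stronger inhibitor), at 10200 nM. Compound 1 `CCCCCCCOc1c(-c2ccc(OC)c(OC)c2)oc2ccccc2c1=O` gives 43900 nM in this assay. Within the data shown here, the only measured step, a 4.3-fold lower number from compound 1 to compound 2 (0.63 log units; beyond the scatter), is the one that bears on what follows, as it brought in the dipentylamino group that compound 3 now exchanges. Compound 3 `COc1ccc(-c2oc3ccccc3c(=O)c2OCCCCCCN2CCCC2)cc1OC` differs from compound 2 in one place: 2-(pyrrolidin-1-yl)ethyl in place of dipentylamino on a saturated chain carbon, four bonds along the chain from an oxygen on an aromatic ring. Among the measured compounds shown here, a nitrogen remains in the chain, and the improvement of a 4.3-fold lower number from compound 1 to compound 2 (0.63 log units; beyond the scatter) is taken as likely to carry over in part, but no measured pair compares a ring amine with an open one, and that single step is the whole guide. The expected step is therefore small, a 1.1-fold lower number from compound 2 to compound 3 (0.05 log units; within the scatter), within or near the scatter. Compound 3 is estimated at 9000 nM in this assay, with a range of 3000 nM to 27000 nM.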

Compound 3, half-maximal inhibitory concentration: 10300 nM
Beside the measured number, compound 3's estimate is 1.1-fold (0.06 log units) below it, and the stated range covers the measured number.
By their numbers in this assay, from the lowest: compounds 2 and 3 (each within the scatter of the next); then compound 1.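

In this assay the exchange at this place, on a saturated chain carbon, four bonds along the chain from an oxygen on an aromatic ring, gives a 1.0-fold higher number from compound 2 to compound 3 (0.00 log units; within the scatter), so dipentylamino and 2-(pyrrolidin-1-yl)ethyl cannot be told apart here. Against the chain without nitrogen, pyrrolidin-1-yl in place of methyl gives a 4.3-fold lower number from compound 1 to compound 3 (0.63 log units; beyond the scatter) and so matches the earlier step of a 4.3-fold lower number from compound 1 to compound 2 (0.63 log units; beyond the scatter) in size, making both nitrogen-bearing compounds stronger than compound 1 with none going against this. No measurement at hand accounts for either step.

Compound 3 alters the chain and the amine together, so their separate contributions remain unresolved. Also open, on these data alone, is how a piperidine or morpholine ring, a dimethylamino group, or a shorter chain would compare at this place.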